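The source may report more compounds than this note shows. Statements on the series, on what has been measured and on what is new or still open speak of the compounds shown alone.

Working notes on the series, read in a functional assay on DU-145 cells (Homo sapiens) for inhibition, read by sulforhodamine B assay, with a stated time of 48 h; on this read-out higher numbers stand for weaker inhibition of growth and lower numbers for stronger inhibition of growth. Compound 1 `COc1cc(C(=O)NNC(=O)c2ccc3[nH]c(-c4ccc([N+](=O)[O-])s4)nc3c2)cc(OC)c1OC` gives 62.5 ug/mL. Compound 3 `O=C(NNC(=O)c1cc2ccccc2cc1O)c1ccc2[nH]c(-c3ccc([N+](=O)[O-])s3)nc2c1` gives 62.5 ug/mL, level with compound 1 at the digits available. Compound 2 `O=C(O)c1ccc2[nH]c(-c3ccc([N+](=O)[O-])o3)nc2c1` gives 125 ug/mL, within the scatter of compound 1, so the three values do not separate.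

Compound 4 `COc1cc(C(=O)NNC(=O)c2ccc3[nH]c(-c4ccc([N+](=O)[O-])o4)nc3c2)cc(OC)c1OC` follows from compound 1 by a single change: 5-nitrofuran-2-yl in place of 5-nitrothiophen-2-yl on an aromatic carbon. This places 5-nitrofuran-2-yl in place of 5-nitrothiophen-2-yl on an aromatic carbon, and the heavy-atom count stays the same. Among the compounds with values here, no pair of measured compounds differs in one place only, so the series gives no direct measure of this swap. Within the data shown here, the only indirect evidence is compound 2, which carries the 5-nitrofuran-2-yl group and gives 125 ug/mL, although it differs from compound 1 elsewhere as well. On that basis, no step beyond the scatter is expected in this assay. The expected step is no change at the digits printed from compound 1 to compound 4 (within the scatter). For compound 4 the estimated value is 62.5 ug/mL, with an estimated range of 31 ug/mL to 125 ug/mL.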

Compound 4, concentration for 50% growth inhibition: 15.6 ug/mL
For compound 4 the middle estimate is 4.0-fold (0.60 log units) above the measured one; the measured number lies below the stated range.
By their numbers in this assay, from the lowest: compound 4; then compounds 1, 3 and 2 (each within the scatter of the next).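

Within the data shown here, this is the first pair that differs in one place only. In this assay, 5-nitrofuran-2-yl in place of 5-nitrothiophen-2-yl on an aromatic carbon gives a 4.0-fold lower number from compound 1 to compound 4 (0.60 log units; beyond the scatter), so this position responds to the identity of the five-membered ring even though the heavy-atom count stays the same and only sulfur gives way to oxygen. Nothing at hand bears on the origin of this step.

Going by these compounds, the step is read on one side chain only, and it remains open whether it would hold for the hydroxynaphthalene side chain of compound 3 or the carboxylic acid of compound 2. Also open, on these data alone, is how this position would respond to an amine or a nitrile in place of the nitro group on the furan.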